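Small aryl swaps on a weakly active series

The compounds below may be only part of what the source reports. "The series", "measured", "known", "first", "only" and "open" are said of these compounds alone.

In a functional assay on A549 cells (Homo sapiens) for inhibition, read by MTT assay, with a stated time of 72 h (a higher number here means a weaker inhibitor, a lower number a stronger inhibitor), the measured compounds are these.
- Compound 1 `Cc1cc2occ(-c3nc(-c4ccccc4)c(-c4ccccc4)n3-c3ccc(Br)cc3)c(=O)c2cc1Cl` (25000 nM)
- Compound 2 `Cc1ccc(-n2c(-c3coc4cc(C)c(Cl)cc4c3=O)nc(-c3ccccc3)c2-c2ccccc2)cc1` (12500 nM)
- Compound 3 `Cc1cc2occ(-c3nc(-c4ccccc4)c(-c4ccccc4)n3-c3cccc(Cl)c3)c(=O)c2cc1Cl` (25000 nM)

Compound 3 stands level with compound 1 on these numbers, and compound 2 lies within the scatter of both. The next compound, compound 4 `COc1cccc(-n2c(-c3coc4cc(C)c(Cl)cc4c3=O)nc(-c3ccccc3)c2-c2ccccc2)c1`, keeps the shared core and differs from compound 3 in one group: methoxy in place of chloro on an aromatic carbon (methoxy in place of chloro on an aromatic carbon, meta to a large group, so 3-chlorophenyl becomes 3-methoxyphenyl).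

For the measured compounds named here, no measured step makes this exact swap. The nearest evidence comes from changes to the same aryl group, and these are small: no change at the digits printed from compound 1 to compound 3 (within the scatter), a 2.0-fold higher number from compound 2 to compound 3 (0.30 log units; within the scatter) and a 2.0-fold lower number from compound 1 to compound 2 (0.30 log units; within the scatter). All three stay within the scatter, so no step beyond the scatter is expected in this assay, and no direction is clearly favoured. The estimate amounts to a 1.4-fold lower number from compound 3 to compound 4 (0.14 log units; within the scatter) and remains only an expectation. Compound 4 is expected at about 18000 nM, with an estimated range from 8000 nM to 40000 nM.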

Compound 4, half-maximal inhibitory concentration: 6250 nM
Compound 4: middle estimate off by 2.9-fold (0.46 log units), on the high side; measured number below the stated range.
By their numbers in this assay, from the lowest: compounds 4, 2, 1 and 3 (each within the scatter of the next, the first and the last beyond it).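

In this assay, for the compounds shown here, the earlier changes to this aryl group all stayed within the scatter, while methoxy in place of chloro gives the first step beyond it, a 4.0-fold lower number from compound 3 to compound 4 (0.60 log units; beyond the scatter). The 3-methoxyphenyl group in place of 4-bromophenyl gives a step of the same size, a 4.0-fold lower number from compound 1 to compound 4 (0.60 log units; beyond the scatter), so changes to this aryl group can shift the number, though only modestly. The remaining comparison, a 2.0-fold lower number from compound 2 to compound 4 (0.30 log units; within the scatter), stays within the scatter, so those two compounds cannot be ranked, and no measurement shown explains what methoxy does here.

It remains open whether this step is specific to methoxy, as the compounds shown include no hydroxyl, ethoxy or amine in its place. Also open, going by these compounds, is whether methoxy would give a similar step elsewhere on this aryl ring.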